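Dimethylamino for fluoro on a quinazolinone: an unreadable step

The source may report more compounds than this note shows. Statements on the series, on what has been measured and on what is new or still open speak of the compounds shown alone.

Measured compounds:
- compound 1 `Cc1ccc2nc(-c3ccccc3N(C)C)[nH]c(=O)c2c1`, in a functional assay on HCT-15 cells (Homo sapiens) for cytotoxicity, read by MTT assay, with a stated time of 2 days (a higher number here means a weaker inhibitor, a lower number a stronger inhibitor), compound 1 gives > 50000 nM, which is a limit of the assay and not a number.
- compound 2 `Cc1ccc2c(=O)[nH]c(-c3ccccc3F)nc2c1`: compound 2 gives 10300 nM.
- compound 3 `Cc1ccc2nc(-c3ccccc3F)[nH]c(=O)c2c1`: compound 3 gives > 50000 nM, again a limit and not a number.

Compound 2 and compound 3 are built from the same atoms joined differently; how the two cores differ is not broken down here. Going by the values given here, compound 2 gives the only number among the three values, while the other two sit at the limit (the limit of > 50000 nM in this assay, at which 2 of the 3 values shown sit).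

From compound 3 to compound 1 the change is dimethylamino in place of fluoro on an aromatic carbon. The size of that step, a step that the two limits leave unreadable from compound 3 to compound 1, cannot be read, since both compounds sit at the limit.

Compound 4 `Cc1ccc2c(=O)[nH]c(-c3ccccc3N(C)C)nc2c1` has not yet been measured. It arises from compound 2 by the same change, (dimethylamino in place of fluoro on an aromatic carbon). For compound 4 a step of a 2.4-fold higher number from compound 2 to compound 4 (0.39 log units; beyond the scatter) is expected, a guess with wide bounds because the size of a step that the two limits leave unreadable from compound 3 to compound 1 is not readable. Compound 4 is therefore estimated at 25000 nM, between 5000 nM and 80000 nM.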

Compound 4, half-maximal inhibitory concentration: 12800 nM
Compound 4: the middle estimate sits 2.0-fold (0.29 log units) above what was measured; the range from low to high includes it.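

In this assay, the step on the core of compound 2 is a 1.2-fold higher number from compound 2 to compound 4 (0.09 log units; within the scatter), so on this core the two groups cannot be told apart. This is one pair on one core, and it says nothing about whether dimethylamino and fluoro would also read alike on the core of compound 3. That core offers no number to set beside this step. The pair on that other core cannot be read, because both of its compounds sit at a value that is a limit and not a number: the limit of > 50000 nM in this assay, at which 2 of the 4 values shown sit.

The compounds shown carry only fluoro or dimethylamino at this place on the aromatic ring, so it stays open how a plain amino group or a carboxylic acid would read there on the core of compound 2. From the compounds shown here alone, it also stays open whether any group on the core of compound 3 would give a real number, which is what a readable step on that core would need.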